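Swapping Bromo for Methyl in Compound 3

A few compounds are considered here, and "the series" means these few. Any claim that something is new, unique, unknown or untested is made for them only; others in the source may bear on it.

- Compound 1 `COc1ccc(C2=C(c3ccc(SC)cc3)CC3CCCN3C2=O)cc1Br` gives 5000 nM
- Compound 2 `COc1ccc(C2=C(c3ccc(SC)cc3)CC3CCCN3C2=O)cc1` gives 3000 nM
- Compound 3 `CSc1ccc(C2=C(c3ccc(Br)cc3)C(=O)N3CCCC3C2)cc1` gives 7000 nM

All three values come from a functional assay on SW-620 cells (Homo sapiens) for cytotoxicity; on this read-out higher numbers stand for weaker inhibition of growth and lower numbers for stronger inhibition of growth. Compound 3 sits close to compound 1, with a 1.4-fold higher number from compound 1 to compound 3 (0.15 log units; within the scatter). Compound 2 stands apart from compound 3, with a 2.3-fold higher number from compound 2 to compound 3 (0.37 log units; beyond the scatter).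

The next compound is compound 4 `CSc1ccc(C2=C(c3ccc(C)cc3)C(=O)N3CCCC3C2)cc1`. It differs from compound 3 as follows: methyl in place of bromo on an aromatic carbon. In words, this is methyl in place of bromo on an aromatic carbon, para to a large group.

Going by the values given here, no compound measured so far carries this methyl, so the evidence is indirect. The closest comparison is the swap between methoxy and bromo, seen in a 2.3-fold higher number from compound 2 to compound 3 (0.37 log units; beyond the scatter), which is a modest change. Removing bromo altogether gives a 1.7-fold lower number from compound 1 to compound 2 (0.22 log units; within the scatter), a change that does not clear the scatter. Small changes of this kind have therefore moved the number only slightly in these three compounds. A small step is expected in this assay, probably toward a somewhat lower number and possibly no larger than the scatter. The expected step is a 1.4-fold lower number from compound 3 to compound 4 (0.15 log units; within the scatter). For compound 4 the estimated value is 5000 nM, with an expected range from 2500 nM to 10000 nM.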

Compound 4, concentration for 50% growth inhibition: 3000 nM
Estimate against measurement, compound 4: 1.7-fold (0.22 log units) above, and the stated range covers the measured number.
By their numbers in this assay, from the lowest: compounds 2, 4, 1 and 3 (each within the scatter of the next, the first and the last beyond it).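

Methyl in place of bromo at this position, para to a large group, gives a 2.3-fold lower number from compound 3 to compound 4 (0.37 log units; beyond the scatter), the first direct reading of methyl here, and it shows that a swap of one heavy atom can clear the scatter in this assay. Methyl and methoxy cannot be told apart at this position, with no change at the digits printed from compound 2 to compound 4 (within the scatter), so among the three groups tried here, bromo is the one that stands apart, although the gaps are modest. The 4-methylphenyl group also cannot be ranked against the 3-bromo-4-methoxyphenyl group, as a 1.7-fold lower number from compound 1 to compound 4 (0.22 log units; within the scatter) stays within the scatter, so adding a second substituent and changing the first, taken together, leave no clear mark on the number.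

Nothing measured alongside these values accounts for the difference between bromo and the other two groups. On these data alone, it remains open how an amine, a carboxylic acid or a longer chain such as propyl would read at this position, and whether any group there could move the number by more than these modest steps.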